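The compounds below may be only part of what the source reports. "The series", "measured", "known", "first", "only" and "open" are said of these compounds alone.

Measured compounds in an assay on CHO cells for antagonist activity at transient receptor potential cation channel subfamily V member 1 (Homo sapiens), read by FLIPR; on this read-out higher numbers stand for weaker inhibition and lower numbers for stronger inhibition:
Compound 1, `CC(C(=O)NCc1ccc(C(F)(F)F)cc1N1CCC(C)(C)CC1)c1ccc(NS(C)(=O)=O)c(F)c1`: 1.3 nM
Compound 2, `CC(C(=O)NCc1ccc(C(F)(F)F)cc1N1CCC(Cc2ccc(F)cc2)CC1)c1ccc(NS(C)(=O)=O)c(F)c1`: 0.4 nM
Compound 3, `Cc1cccc(N2CCN(c3cc(C(F)(F)F)ccc3CNC(=O)C(C)c3ccc(NS(C)(=O)=O)c(F)c3)CC2)c1`: 1.8 nM

Among these three, compound 1 holds the second highest number in this assay. Its nearest neighbour is compound 3, whose number is a little higher but within the usual scatter, so the two cannot be told apart. Its furthest neighbour is compound 2, whose lower number lies beyond the scatter.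

Compound 4, `CC(C(=O)NCc1ccc(C(F)(F)F)cc1SCCCO)c1ccc(NS(C)(=O)=O)c(F)c1`, has not yet been measured. It differs from compound 1 in one place: (3-hydroxypropyl)sulfanyl in place of 4,4-dimethylpiperidin-1-yl on an aromatic carbon. Among the measured compounds shown here, no pair of measured compounds differs in exactly one place, so no measured step is at hand to anchor this change. The three measured compounds all carry a six-membered ring with a nitrogen at this position, and the chain entering in compound 4 breaks with that pattern.

Compound 4 is therefore expected to show a weaker result, with an estimated step of a 12-fold higher number from compound 1 to compound 4 (1.06 log units; beyond the scatter) in this assay. The estimate for compound 4 is 15 nM, expected to fall between 3 nM and 80 nM.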

Compound 4, inhibition constant: "not active" (no number reported)
Compound 4: no number reported; there is nothing to compare the estimate with.
By their numbers in this assay, from the lowest: compound 2; then compounds 1 and 3 (each within the scatter of the next).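

In this assay, among the compounds shown here, compound 4 is reported as "not active" without a number, so no step from compound 1 to compound 4 can be read. The compounds shown leave open how much activity is lost, if any measurable amount remains, when (3-hydroxypropyl)sulfanyl replaces 4,4-dimethylpiperidin-1-yl, and nothing given here accounts for the result.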